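Replacing 2-propoxyethoxy with amino on the shared core

A few compounds are considered here, and "the series" means these few. Any claim that something is new, unique, unknown or untested is made for them only; others in the source may bear on it.

In an ADME assay on Huh-7 cells (Homo sapiens) for cytotoxicity, read by MTT assay, with a stated time of 4 h, at 37 degrees C (a higher number here means that more compound is tolerated, a lower number that less compound is tolerated), compound 1 `CCCOCCOc1nc(N)nc2c1cc(-c1c(Cl)cccc1Cl)c(=O)n2C` gives 50100 nM, the higher of the two numbers available. Compound 2 `Nc1nc(Nc2ccccc2)nc2[nH]c(=O)c(-c3ccccc3)cc12` gives 13800 nM, a gap beyond the usual scatter. Compound 3 `Cn1c(=O)c(-c2c(Cl)cccc2Cl)cc2c(N)nc(N)nc21` keeps the core of compound 1 and differs from it in one place, with amino in place of 2-propoxyethoxy on an aromatic carbon, next to the ring nitrogen (amino in place of 2-propoxyethoxy on an aromatic carbon). Going by the values given here, no measured pair isolates this change, so the expectation in this assay is for no step beyond the scatter, with a slight lean towards a lower number. That lean rests only on compound 2, which carries no 2-propoxyethoxy chain and stands at 13800 nM. The expected move is a 1.3-fold lower number from compound 1 to compound 3 (0.10 log units; within the scatter). For compound 3 the estimated value is 40000 nM, with an expected range from 12000 nM to 110000 nM.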

Compound 3, half-maximal cytotoxic concentration: 120000 nM
Beside the measured number, compound 3's estimate is 3.0-fold (0.48 log units) below it; measured number outside the range, above it.
By their numbers in this assay, from the lowest: compound 2; then compound 1; then compound 3.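

In this assay, amino in place of 2-propoxyethoxy on an aromatic carbon, next to the ring nitrogen, gives a 2.4-fold higher number from compound 1 to compound 3 (0.38 log units; beyond the scatter) on the shared core. Going by these compounds alone, this is the first direct reading of the change at this position, and it shows that the number does not depend on keeping the 2-propoxyethoxy chain there, since the single-atom amino group ends higher. No measurement at hand accounts for the step.

On these data alone, whether a short ether such as methoxy, a hydroxyl, or a substituted amine such as methylamino would stand with compound 1, with compound 3 or between them remains open. So does whether the same change would give a step of similar size on another core, as a single pair cannot settle this.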